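Methoxy Added to the Phenyl of Compound 1

The compounds below may be only part of what the source reports. "The series", "measured", "known", "first", "only" and "open" are said of these compounds alone.

The measured compounds and their numbers:
compound 1, `COc1ccc(-c2nc(C)c(C(=O)CSc3nc(N)c(C#N)c(-c4ccccc4)n3)s2)cc1`, 61.8%;
compound 2, `COc1ccc(-c2nc(C)c(C(=O)CSc3nc(-c4cccc(OC)c4)c(C#N)c(=O)[nH]3)s2)cc1`, 71.3%;
compound 3, `COc1cccc(-c2nc(SCC(=O)c3sc(-c4ccccc4)nc3C)[nH]c(=O)c2C#N)c1`, 99%.

In a functional assay on U-87MG ATCC cells for antiproliferative activity against U-87 MG (Homo sapiens), read by MTT assay, with a stated time of 48 h, tested at 5 uM (a lower number here means a stronger effect, a higher number a weaker effect of the compound at the concentration tested), compound 3 gives 99%, and compound 2 gives 71.3%. The change between them is methoxy in place of hydrogen on an aromatic carbon, and the step it made is a number 27.7 percentage points lower from compound 3 to compound 2 (beyond the scatter). Compound 1 gives 61.8%, close to compound 2 and well apart from compound 3; the difference between the core of compound 1 and the core of compound 3 is not broken down here.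

Compound 4, `COc1ccc(-c2nc(C)c(C(=O)CSc3nc(N)c(C#N)c(-c4ccc(OC)cc4)n3)s2)cc1`, is not yet measured. It differs from compound 1 by methoxy in place of hydrogen on an aromatic carbon, the same change as from compound 3 to compound 2, at the same kind of place. For compound 4 a step of a number 16.8 percentage points lower from compound 1 to compound 4 (beyond the scatter) is expected, smaller than the earlier one because a number 27.7 percentage points lower from compound 3 to compound 2 (beyond the scatter) was seen on a different core and compound 1 already starts from 61.8%. Compound 4 is therefore estimated at 45%, with a likely range from 25% to 65%.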

Compound 4, a percentage reported as activity, at one concentration (the size of the read-out at that concentration, not a potency): 35.6%
Estimate against measurement, compound 4: 9.4 percentage points above; low and high end bracket the measured number.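

In this assay, replacing phenyl with 4-methoxyphenyl gave a number 26.2 percentage points lower from compound 1 to compound 4 (beyond the scatter), and the two steps for adding methoxy are matched in size: the same change on two cores in this assay, a number 27.7 percentage points lower (beyond the scatter) from compound 3 to compound 2 and a number 26.2 percentage points lower (beyond the scatter) from compound 1 to compound 4, 1.5 percentage points apart, within the scatter of two such steps This shows that, for these two pairs, the size of the step held from one core to the other, even though the methoxy goes onto a different phenyl ring of the molecule in each pair. It does not show that the step would hold on any further core or at any other place, and two pairs at a single concentration in one cell line give no account of why the steps match.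

The compounds shown leave open whether a hydroxyl, an amine or a longer chain such as ethoxy, put in place of the methoxy, would give a step of similar size. They also leave open whether the same step would appear at another concentration; each number here is the size of the read-out at one concentration.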